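The source may report more compounds than this note shows. Statements on the series, on what has been measured and on what is new or still open speak of the compounds shown alone.

Of the compounds shown here, two have been measured in an assay on isolated protein for binding affinity to corticotropin-releasing factor receptor 1 (Homo sapiens); on this read-out higher numbers stand for weaker inhibition and lower numbers for stronger inhibition. Compound 1, `CC(=O)/C(=N\c1ccc(Cl)cc1)NNc1ccccc1C`, gives 1830 nM. Compound 2, `CC(=O)/C(=N\c1cccc(C)c1)NNc1ccccc1C`, gives 526 nM. Within the data shown here, the only step between them, a 3.5-fold lower number from compound 1 to compound 2 (0.54 log units; beyond the scatter), changes the group on the double-bonded nitrogen. Compound 2 therefore stands with the lowest of the two numbers, and compound 1 sits a single step above it.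

Compound 3, `CC(=O)/C(=N\c1cccc(C#N)c1)NNc1ccccc1C`, differs from compound 2 in one place: cyano in place of methyl on an aromatic carbon. Among the measured compounds shown here, no measured pair shows a cyano group entering in place of a methyl group, so the only step that bears on this change, a 3.5-fold lower number from compound 1 to compound 2 (0.54 log units; beyond the scatter), is an indirect guide: it shows that altering this same aromatic group moves this assay by a modest amount. A step of similar or smaller size is therefore expected for compound 3, with the direction uncertain, so the estimate for compound 3 is 800 nM, between 250 nM and 2500 nM, which corresponds to an expected step of a 1.5-fold higher number from compound 2 to compound 3 (0.18 log units; within the scatter).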

Compound 3, inhibition constant: > 10000 nM
Compound 3: only a limit was reported; the forecaster's own chance of this, stated with the estimate: 5%; middle value at least 12-fold (1.09 log units) from the limit.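

In this assay, exchanging methyl for cyano at this one place, meta to a large group, gives an at least 19-fold higher number from compound 2 to compound 3 (1.27 log units; beyond the scatter). The earlier step, a 3.5-fold lower number from compound 1 to compound 2 (0.54 log units; beyond the scatter), changed both the group and its place on the ring and moved the number only modestly, whereas this pair holds the place fixed and shows that the group there alone can decide whether binding is detected, even though cyano has only one more heavy atom than methyl. Compound 3 gives only a limit of the assay, not a number, so this step is a minimum and its true size stays unknown: the limit of > 10000 nM in this assay, at which 1 of the 3 values shown sits.

The compounds shown leave open whether this drop belongs to cyano alone or would also follow other groups at this place, such as a methoxy group or an amine. They also leave open how a ring carrying only hydrogen at this place would compare with compound 2.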